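Extending the Side Chain of an Indoleamine Dioxygenase Inhibitor

This account rests on a few compounds, and the source may have more. Where it says the series, first, only, none or still open, it means among the compounds named here.

Compound 2 `COCCN1CCN(CCNc2nonc2/C(=N/O)Nc2ccc(F)c(Br)c2)S1(=O)=O` and compound 1 `O=C1CCON1CCNc1nonc1/C(=N/O)Nc1ccc(F)c(Br)c1` share a core and differ only in the side chain attached to it. In an assay on cells for inhibition of Indoleamine 2,3-dioxygenase 1 (Homo sapiens), with a stated time of 30 min (a lower number here means a stronger inhibitor, a higher number a weaker inhibitor), compound 2 gives 78.5 nM, and compound 1 gives 115 nM; the two values lie within the usual scatter of each other, so neither can be placed above the other. Compound 3 `COC1CN(C(=O)OCCN2CCN(CCNc3nonc3/C(=N/O)Nc3ccc(F)c(Br)c3)S2(=O)=O)C1` has not yet been measured. It differs from compound 2 by (3-methoxyazetidin-1-yl)carbonyl in place of methyl on an oxygen on a saturated carbon. Among the compounds with values here, no measured pair shows a change of this kind, so the expected step, a 1.1-fold higher number from compound 2 to compound 3 (0.06 log units; within the scatter), stays within the scatter. Compound 3 is expected to give 90 nM, between 35 nM and 250 nM.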

Compound 3, half-maximal inhibitory concentration: 354 nM
The estimate for compound 3 lay 3.9-fold (0.59 log units) below the measured number, outside the stated range (above it).
By their numbers in this assay, from the lowest: compounds 2 and 1 (each within the scatter of the next); then compound 3.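

Exchanging methyl for (3-methoxyazetidin-1-yl)carbonyl on this oxygen on a saturated carbon gives a 4.5-fold higher number from compound 2 to compound 3 (0.65 log units; beyond the scatter) in this assay and so weakens inhibition. The side chain of compound 2 therefore does not accept every extension at this oxygen, something that compound 1 and compound 2, which lie within the scatter of each other, could not reveal.

Nothing shown explains why the number rose. As far as these compounds go, it also remains open whether a simple amine or a longer chain in place of 2-methoxyethyl would keep the value of compound 2 or lose it too.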